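Swapping 3-methylphenyl for 1H-indol-6-yl in the series

The compounds below may be only part of what the source reports. "The series", "measured", "known", "first", "only" and "open" are said of these compounds alone.

Values in a functional assay on A549 cells (Homo sapiens) for antiproliferative activity, read by MTT assay, with a stated time of 48 h; a higher number here means a weaker inhibitor, a lower number a stronger inhibitor:
- compound 1 `COc1cc(-c2cccc3nc(-c4cccc(Br)c4)oc23)cc(OC)c1OC`: 2100 nM
- compound 2 `COc1cc(-c2cccc3nc(-c4ccc(Br)cc4)oc23)cc(OC)c1OC`: > 25000 nM (a limit)
- compound 3 `COc1cc(-c2cccc3nc(-c4cccc(C)c4)oc23)cc(OC)c1OC`: 16700 nM

Of the two values that are true numbers, compound 3 has the higher, so it is the weaker of that pair. Compound 4 `COc1cc(-c2cccc3nc(-c4ccc5cc[nH]c5c4)oc23)cc(OC)c1OC` differs from it in one group: 1H-indol-6-yl in place of 3-methylphenyl on an aromatic carbon. Two measured steps in this same group bear on the change: an 8.0-fold higher number from compound 1 to compound 3 (0.90 log units; beyond the scatter) and an at least 11-fold higher number from compound 1 to compound 2 (1.07 log units; beyond the scatter). Both are beyond the scatter, so the number responds strongly to this group, but neither step involves an indole. A modest move towards a lower number is expected, with low confidence, given the high value of compound 3 at 16700 nM. The expected change is a 2.4-fold lower number from compound 3 to compound 4 (0.38 log units; beyond the scatter). Compound 4 is estimated at 7000 nM, with an expected range of 1500 nM to 25000 nM.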

Compound 4, half-maximal inhibitory concentration: 55 nM
The estimate for compound 4 lay 130-fold (2.10 log units) above the measured number; the whole stated range lies above it.
By their numbers in this assay, from the lowest: compound 4; then compound 1; then compound 3. At a limit, above all of these: compound 2.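

In this assay, 1H-indol-6-yl on this aromatic carbon reaches a potency that neither 3-bromophenyl nor 3-methylphenyl approaches: a 300-fold lower number from compound 3 to compound 4 (2.48 log units; beyond the scatter) and a 38-fold lower number from compound 1 to compound 4 (1.58 log units; beyond the scatter). The response at this position is therefore far wider than the phenyl compounds alone indicated. The step of an at least 450-fold lower number from compound 2 to compound 4 (2.65 log units; beyond the scatter) is only a floor, set by a limit: the limit of > 25000 nM in this assay, at which 1 of the 4 values shown sits.

The compounds shown do not separate the contribution of the indole hydrogen-bond donor from that of the fused ring. A 1-methyl-1H-indol-6-yl group or an aminophenyl group would test this.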